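Swapping the aryl ether cap: compound 3 to compound 4

A few compounds are considered here, and "the series" means these few. Any claim that something is new, unique, unknown or untested is made for them only; others in the source may bear on it.

Three compounds share one core and differ only in the aromatic group attached through an oxygen on a saturated carbon. Compound 1 `CC(C)[C@H](NC(=O)COc1cccc2ccccc12)C(=O)N[C@@H](CC(=O)O)C(=O)COc1cccc2ccccc12` gives 19000 nM in a functional assay with Homo sapiens as the target; a lower number here means a stronger inhibitor, a higher number a weaker inhibitor. Compound 2 `CC(C)[C@H](NC(=O)COc1cccc2ccccc12)C(=O)N[C@@H](CC(=O)O)C(=O)COc1ccc2ccccc2c1` gives 15900 nM in this assay, and compound 3 `CC(C)[C@H](NC(=O)COc1cccc2ccccc12)C(=O)N[C@@H](CC(=O)O)C(=O)COc1ccccc1[N+](=O)[O-]` gives 27700 nM. None of these numbers is separated from another beyond the usual scatter: a 1.2-fold lower number from compound 1 to compound 2 (0.08 log units; within the scatter), a 1.5-fold higher number from compound 1 to compound 3 (0.16 log units; within the scatter), and a 1.7-fold higher number from compound 2 to compound 3 (0.24 log units; within the scatter). Compound 3 therefore stands among its neighbours rather than apart from them.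

Compound 4 `CC(C)[C@H](NC(=O)COc1cccc2ccccc12)C(=O)N[C@@H](CC(=O)O)C(=O)COc1cc(F)cc(F)c1` is not yet measured. Its difference from compound 3 is 3,5-difluorophenyl in place of 2-nitrophenyl on an oxygen on a saturated carbon. This is the same kind of change seen in the three measured steps, each of which replaced the group on that oxygen and each of which stayed within the scatter. On that basis, no step beyond the scatter is expected from compound 3 to compound 4, so a 1.3-fold lower number from compound 3 to compound 4 (0.10 log units; within the scatter) is the expected outcome. Compound 4 is therefore estimated at 22000 nM in this assay, with a likely range from 9000 nM to 55000 nM.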

Compound 4, half-maximal inhibitory concentration: 15900 nM
For compound 4 the middle estimate is 1.4-fold (0.14 log units) above the measured one; the range from low to high includes it.
By their numbers in this assay, from the lowest: compounds 2, 4, 1 and 3 (each within the scatter of the next).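

In this assay, the exchange of the ring gives a 1.7-fold lower number from compound 3 to compound 4 (0.24 log units; within the scatter), even though 2-nitrophenyl counts 2 hydrogen-bond acceptors and 3,5-difluorophenyl counts 0. So, at this position, the nitro group is not needed to keep the number in the range seen so far, and a single benzene ring can carry fluorine instead. The new group also matches both naphthalene-based compounds, with no change at the digits printed from compound 2 to compound 4 (within the scatter) and a 1.2-fold lower number from compound 1 to compound 4 (0.08 log units; within the scatter); across these four compounds, then, aryl groups on an oxygen on a saturated carbon have produced no step beyond the scatter, although no measurement here explains why they read alike.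

As far as these compounds go, all four groups placed here are aromatic and uncharged, so it remains open whether this position is insensitive to change in general or only to exchanges among such rings. An amine on the ring, or a longer saturated chain in place of the ring, would test that more severely, and either could show whether any group on this oxygen moves the number beyond the scatter.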